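Methoxy substitution on a cyclopropyl-benzimidazole pyridine series

The source may report more compounds than this note shows. Statements on the series, on what has been measured and on what is new or still open speak of the compounds shown alone.

Compound 1 `Fc1cc2nc(-c3cccnc3)n(C3CC3)c2cc1F` is the reference point of the set. In an assay on V79 cells for inhibition of cytochrome P450 11B1, mitochondrial (Homo sapiens), read by HTRF, with a stated time of 1 h (on this read-out higher numbers stand for weaker inhibition and lower numbers for stronger inhibition), compound 1 gives 370 nM, the lowest of the two numbers recorded. Compound 2 `c1cncc(-c2nc3ccccc3n2C2CC2)c1` carries the unsubstituted core; in this assay compound 2 reaches only the limit > 8330 nM, so no number is known for it (the limit of > 8330 nM in this assay, at which 1 of the 3 values shown sits). Compound 3 `COc1ccc2nc(-c3cccnc3)n(C3CC3)c2c1` gives 1980 nM in this assay. Within the data shown here, the single change between them, (methoxy in place of hydrogen on an aromatic carbon), yields an at least 4.2-fold lower number from compound 2 to compound 3 (0.62 log units; beyond the scatter). The cores of compound 1 and compound 2 differ in more than one place, and the difference between them is not broken down here; of the two measured numbers, compound 1 stands at 370 nM and compound 3 stands at 1980 nM.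

Compound 4 `COc1cncc(-c2nc3cc(F)c(F)cc3n2C2CC2)c1` has not yet been measured. It differs from compound 1 by methoxy in place of hydrogen on an aromatic carbon. Among the measured compounds shown here, this is the same kind of change as the one from compound 2 to compound 3, not the same change: there the methoxy entered a six-membered aromatic ring of carbon only, part of a fused system, meta and para to a fused ring; here it enters a six-membered aromatic ring with one nitrogen, two atoms from the ring nitrogen, meta to a large group. The expectation is a step of a 1.2-fold higher number from compound 1 to compound 4 (0.09 log units; within the scatter), smaller than an at least 4.2-fold lower number from compound 2 to compound 3 (0.62 log units; beyond the scatter), because an at least 4.2-fold lower number from compound 2 to compound 3 (0.62 log units; beyond the scatter) was obtained at a different place on the molecule and compound 1 already sits at 370 nM. Compound 4 is expected to give about 450 nM in this assay, most likely between 150 nM and 1800 nM.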

Compound 4, half-maximal inhibitory concentration: 250 nM
For compound 4 the middle estimate is 1.8-fold (0.26 log units) above the measured one; the range from low to high includes it.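

In this assay, among these compounds, methoxy in place of hydrogen on an aromatic carbon, two atoms from the ring nitrogen, gives a 1.5-fold lower number from compound 1 to compound 4 (0.17 log units; within the scatter), so on the core of compound 1 this change produces no step that stands out from repeated measurement. The change does not carry from one core to another at a single size, yet the methoxy also sits on a different ring in each pair, and these two steps cannot separate the effect of place from that of core: the same change on two cores in this assay, an at least 4.2-fold lower number (0.62 log units; beyond the scatter) from compound 2 to compound 3 and a 1.5-fold lower number (0.17 log units; within the scatter) from compound 1 to compound 4, at least 2.8-fold (0.45 log units) apart, beyond the scatter of two such steps Compound 2 is known only through a limit, so the earlier step has a lower bound on its size and no measured size of its own: the limit of > 8330 nM in this assay, at which 1 of the 4 values shown sits.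

On these data alone, it remains open what methoxy would do at the place it holds in compound 4 on the core of compound 2, the comparison that would keep the place fixed and vary the core. Also open, as far as these compounds go, is how a hydroxyl, an amine or a longer alkoxy chain at that same place would read in this assay.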